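This account rests on a few compounds, and the source may have more. Where it says the series, first, only, none or still open, it means among the compounds named here.

Measured so far in a functional assay on FM3A cells (Mus musculus) for antiproliferative activity, read by cell counting, with a stated time of 2 days; on this read-out higher numbers stand for weaker inhibition and lower numbers for stronger inhibition
Compound 1 (`COc1ccc(Nc2nc(N)c(C(=O)c3ccccc3)s2)cc1`) gives 730 nM
Compound 2 (`COc1ccccc1C(=O)c1sc(Nc2ccccc2)nc1N`) gives 1100 nM

In this assay compound 2, at 1100 nM, lies within the usual scatter of compound 1, at 730 nM, so the two numbers cannot be told apart. Compound 3 (`COc1ccc(Nc2nc(N)c(C(=O)c3ccccc3OC)s2)cc1`) follows from compound 2 through methoxy in place of hydrogen on an aromatic carbon in all: methoxy in place of hydrogen on an aromatic carbon, para to a large group, which reads as phenyl to 4-methoxyphenyl when cut one bond further out. For the measured compounds named here, no pair of measured compounds shows this change alone. Compound 1 carries the 4-methoxyphenyl group and still gives 730 nM, so the new group is not expected to weaken inhibition much. Going by the values given here, with only two values, this is thin support. A modest step of a 2.0-fold lower number from compound 2 to compound 3 (0.30 log units; within the scatter) is expected, towards a lower number, and its size is expected to lie near the edge of the scatter. Compound 3 is estimated at 550 nM in this assay, with an expected range from 150 nM to 1800 nM.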

Compound 3, half-maximal inhibitory concentration: 52 nM
For compound 3 the middle estimate is 11-fold (1.02 log units) above the measured one; measured number outside the range, below it.
By their numbers in this assay, from the lowest: compound 3; then compounds 1 and 2 (each within the scatter of the next).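

In this assay, methoxy in place of hydrogen on an aromatic carbon, para to a large group, which reads as phenyl to 4-methoxyphenyl, gives a 21-fold lower number from compound 2 to compound 3 (1.33 log units; beyond the scatter) and so has far more effect here than compound 1 alone suggested. The same kind of replacement, made on the other aromatic ring, gives a 14-fold lower number from compound 1 to compound 3 (1.15 log units; beyond the scatter) and is likewise large, so compound 3, the only compound shown with both methoxy groups, lies beyond the scatter of each compound that has only one. Nothing available accounts for the size of either step.

The compounds shown include no counterpart of the shared core without any methoxy group, so they leave open what each methoxy group does on its own and whether the two steps depend on each other. They also leave open whether ethoxy, hydroxy, fluorine or an amine in place of either methoxy group would keep inhibition in this range, and whether a methoxy group elsewhere on either aromatic ring would do the same.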